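The compounds below may be only part of what the source reports. "The series", "measured", "known", "first", "only" and "open" are said of these compounds alone.

Measured so far in a functional assay, read by spectrophotometry, with a stated time of 1 h; a higher number here means a weaker inhibitor, a lower number a stronger inhibitor:

Compound 1, `Cc1ccc2[nH]c(=O)c(/C=N/Nc3ccc([N+](=O)[O-])cc3)cc2c1`: 350000 nM
Compound 2, `Cc1ccc2[nH]c(=O)c(/C=N/Nc3ccc([N+](=O)[O-])cc3[N+](=O)[O-])cc2c1`: 749000 nM
Compound 3, `Cc1ccc2[nH]c(=O)c(/C=N/Nc3ccccc3)cc2c1`: 1470000 nM

Compound 2 holds the second highest of the three numbers in this assay. Its nearest neighbour is compound 3, whose number lies within the scatter of that of compound 2, so the two cannot be ordered. Its furthest neighbour is compound 1, from which it is separated by a 2.1-fold higher number from compound 1 to compound 2 (0.33 log units; beyond the scatter), a step that does lie beyond the scatter. The other measured step, a 4.2-fold higher number from compound 1 to compound 3 (0.62 log units; beyond the scatter), also concerns the nitro groups on the aniline-derived ring.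

Compound 4, `O=c1[nH]c2ccccc2cc1/C=N/Nc1ccc([N+](=O)[O-])cc1[N+](=O)[O-]`, differs from compound 2 by hydrogen in place of methyl on an aromatic carbon. Neither measured step touches the methyl on the fused ring system: both alter a nitro group on the other ring, so neither bears on this change. Going by the values given here, with no measured step to lean on, the expected step is none beyond the scatter, and the number of compound 4 is estimated to sit at that of compound 2, with the range widened to reflect the missing precedent. The expected step is a 1.0-fold higher number from compound 2 to compound 4 (0.00 log units; within the scatter). For compound 4 the estimate in this assay is 750000 nM, with a range from 300000 nM to 1900000 nM.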

Compound 4, half-maximal inhibitory concentration: 375000 nM
Beside the measured number, compound 4's estimate is 2.0-fold (0.30 log units) above it; measured number inside the range.
By their numbers in this assay, from the lowest: compounds 1, 4, 2 and 3 (each within the scatter of the next, the first and the last beyond it).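

Hydrogen in place of methyl on an aromatic carbon of the fused system gives a 2.0-fold lower number from compound 2 to compound 4 (0.30 log units; within the scatter) in this assay and is the first measured step at this position, since the earlier steps concerned only the nitro groups on the other ring. With both nitro groups of compound 2 in place, methyl and hydrogen at this position cannot be told apart, so the methyl is not shown to matter to the number in this assay, though this rests on a single pair. No supporting data bear on the interpretation of this step.

Going by these compounds, how the position behaves with other substitution on the other ring remains open. Going by these compounds alone, the change is read only against the two nitro groups of compound 2 and not against the single nitro group of compound 1 or the unsubstituted ring of compound 3. Also open, on these data alone, is whether the position responds to anything other than methyl or hydrogen, such as a methoxy group, an amine, a carboxylic acid or a longer alkyl chain.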